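The source may report more compounds than this note shows. Statements on the series, on what has been measured and on what is new or still open speak of the compounds shown alone.

Series notes, shared core throughout; the ester group on the second hydroxyl of the core is what varies. Compound 1 `CC(=O)Oc1ccccc1C(=O)O[C@H]1CO[C@H]2[C@@H]1OC[C@H]2OC(=O)c1ccnn1C` carries 1-methyl-1H-pyrazol-5-yl there, and in an ADME assay on a cell-free system (plasma, Homo sapiens) for metabolic stability, with Plasma (Rattus norvegicus) as the target, read by HPLC, at pH 7.4 (a higher number here means that the compound lasts longer, a lower number that the compound disappears faster), compound 1 gives 0.0963 h. For the measured compounds named here, compound 2 `CC(=O)Oc1ccccc1C(=O)O[C@H]1CO[C@H]2[C@@H]1OC[C@H]2OC(=O)c1ccc(O)cc1` carries 4-hydroxyphenyl, and in this assay compound 2 gives 0.0198 h, the lowest of the three numbers measured so far. Compound 3 `CC(=O)Oc1ccccc1C(=O)O[C@H]1CO[C@H]2[C@@H]1OC[C@H]2OC(=O)c1ccc(C)cc1` carries 4-methylphenyl; in this assay compound 3 gives 0.105 h. Going by the values given here, two steps touch compound 2: a 4.9-fold lower number from compound 1 to compound 2 (0.69 log units; beyond the scatter), and a 5.3-fold higher number from compound 2 to compound 3 (0.72 log units; beyond the scatter). Between the other two, a 1.1-fold higher number from compound 1 to compound 3 (0.04 log units; within the scatter).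

Compound 4 `CC(=O)Oc1ccccc1C(=O)O[C@H]1CO[C@H]2[C@@H]1OC[C@H]2OC(=O)c1cccnc1` is the next member. Relative to compound 2 the change is pyridin-3-yl in place of 4-hydroxyphenyl on a carbonyl carbon. The step into compound 4 removes the hydroxy, and the two measured compounds without a hydroxy, compound 1 and compound 3, sit together at the higher level. On that basis compound 4 is expected to return to that level, with a 4.5-fold higher number from compound 2 to compound 4 (0.66 log units; beyond the scatter) expected in this assay. The estimate for compound 4 is 0.09 h, with a range from 0.04 h to 0.2 h.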

Compound 4, half-life: 0.0232 h
Beside the measured number, compound 4's estimate is 3.9-fold (0.59 log units) above it, outside the stated range (below it).
By their numbers in this assay, from the lowest: compounds 2 and 4 (each within the scatter of the next); then compounds 1 and 3 (each within the scatter of the next).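

In this assay, taking the hydroxy out of this ester group does not by itself lift the number, with a 1.2-fold higher number from compound 2 to compound 4 (0.07 log units; within the scatter). Compound 4 instead stands apart from the other two compounds without a hydroxy, with a 4.5-fold lower number from compound 3 to compound 4 (0.66 log units; beyond the scatter) and a 4.2-fold lower number from compound 1 to compound 4 (0.62 log units; beyond the scatter), so compound 4 goes against a split of this position into hydroxy-bearing and hydroxy-free groups, and compound 2 and compound 4 now form the lower level. Nothing at hand accounts for this grouping.

For the compounds shown here, four compounds cannot show what the lower level shares, as 4-hydroxyphenyl and pyridin-3-yl are the only two groups at that level. Plain phenyl, 4-aminophenyl and pyridin-4-yl on the same carbonyl carbon would test how far that level extends.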